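Phenyl for ethoxy at the assay limit

The compounds below may be only part of what the source reports. "The series", "measured", "known", "first", "only" and "open" are said of these compounds alone.

For the measured compounds named here, in a functional assay on THP-1 cells (Homo sapiens) for inhibition, read by sulforhodamine B assay, with a stated time of 48 h (a higher number here means a weaker inhibitor, a lower number a stronger inhibitor), compound 1 (`COC(=O)[C@@]1(C)C[C@@H](c2coc3ccc(Br)cc3c2=O)N(c2ccccc2)O1`) gives 14700 nM as the only measured number so far. Compound 2 (`CCO[C@H]1C[C@@H](c2coc3ccccc3c2=O)N(c2ccccc2)O1`) gives > 60000 nM as its result, which is a limit and not a number. Compound 3 (`CCO[C@H]1C[C@@H](c2coc3ccc(F)cc3c2=O)N(c2ccccc2)O1`) gives > 60000 nM as its result, again a limit. Both compounds therefore stand at the limit of > 60000 nM in this assay, at which 2 of the 3 values shown sit, in the data so far. Fluoro in place of hydrogen on an aromatic carbon is a step that the two limits leave unreadable from compound 2 to compound 3 and offers no size to carry forward.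

Compound 4 (`O=c1c([C@@H]2C[C@H](c3ccccc3)ON2c2ccccc2)coc2ccccc12`) puts phenyl in place of ethoxy on a saturated ring carbon of compound 2: phenyl in place of ethoxy on a saturated ring carbon is the change. Going by the values given here, no measured step covers this swap. Among the compounds with values here, compound 1 at 14700 nM shows only that a number can be reached, and it differs from compound 2 in more than one place. The expected at least 1.5-fold lower number from compound 2 to compound 4 (0.17 log units; that floor lies within the scatter) is a modest move towards stronger inhibition, and a further limit remains quite possible. Compound 4 is estimated at 40000 nM in this assay, with an expected range from 15000 nM to 60000 nM here.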

Compound 4, half-maximal inhibitory concentration: > 60000 nM
Compound 4: a limit, no number (the forecaster's own chance of this, stated with the estimate: 55%); middle value at least 1.5-fold (0.17 log units) away from the limit.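

In this assay compound 2 and compound 4 each give a limit and not a number, so no step can be read between them. The compounds shown leave open whether phenyl in place of ethoxy on a saturated ring carbon changes inhibition at all.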